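Urea-pyrimidine series: step from compound 2 to compound 4

A few compounds are considered here, and "the series" means these few. Any claim that something is new, unique, unknown or untested is made for them only; others in the source may bear on it.

Measured so far in a functional assay on NCI-H1581 cells (Homo sapiens) for inhibition, read by MTT assay, with a stated time of 48 h, tested at 10 uM; on this read-out higher numbers stand for more inhibition at the one concentration tested (going by the name of the read-out) and lower numbers for less inhibition:
- compound 1, `Cc1ccc(Nc2cc(NC(=O)Nc3c(Cl)cccc3Cl)ncn2)cc1F`, gives 45.3%
- compound 2, `CCc1cccc(Nc2cc(NC(=O)Nc3cc(OC)cc(OC)c3)ncn2)c1`, gives 27.7%
- compound 3, `COc1cc(Nc2cc(NC(=O)Nc3c(Cl)cccc3Cl)ncn2)cc(OC)c1`, gives 68%

Compound 2 holds the lowest of the three numbers in this assay. Its nearest neighbour is compound 1, whose number lies higher by a gap beyond the scatter; compound 3 lies higher still, also beyond the scatter. No pair among the three differs in a single place, so no step between measured compounds can be read off, and no cause is assigned to the gaps.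

Compound 4, `COc1cc(NC(=O)Nc2cc(Nc3cc(C)cc(F)c3)ncn2)cc(OC)c1`, has not been measured. Relative to compound 2 the change is 3-fluoro-5-methylphenyl in place of 3-ethylphenyl on a nitrogen on an aromatic ring; cut one bond further out it reads (3-ethylphenyl)amino to (3-fluoro-5-methylphenyl)amino. The rest of the molecule, including the urea and the shared core, is unchanged.

Nothing measured in this set isolates this exchange, so the expectation rests on compound 2 alone. The step from compound 2 to compound 4 is expected to be small, a number 6.3 percentage points higher from compound 2 to compound 4 (within the scatter), within or only just beyond the scatter in this assay. Compound 4 is therefore estimated at 34%, with a range from 15% to 55%.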

Compound 4, a percentage reported as inhibition, at one concentration (the size of the read-out at that concentration, not a potency): 28.3%
Compound 4: the middle estimate sits 5.7 percentage points above what was measured; low and high end bracket the measured number.
By their numbers in this assay, from the lowest: compounds 2 and 4 (each within the scatter of the next); then compound 1; then compound 3.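

In this assay the series gains its first step in a single place: with 3-fluoro-5-methylphenyl in place of 3-ethylphenyl on a nitrogen on an aromatic ring, the result is a number 0.6 percentage points higher from compound 2 to compound 4 (within the scatter) and the two compounds are not separated on this read-out. With the urea and the shared core held fixed, this position therefore accepts either of these two aryl groups, which match in their computed heavy-atom count and carry no hydrogen-bond donors or acceptors, without a readable difference in the number. No measured property in hand accounts for this result.

Steps from this pair to compound 1 and compound 3 cannot be read, since those compounds differ from the pair in more than one place, so the same exchange remains untested on the other urea partner. On these data alone, it also remains open whether a group of another kind on this nitrogen, such as an aminoalkyl chain, a carboxylic acid or a longer alkyl chain on the aromatic ring, would move the number beyond the scatter.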